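The source may report more compounds than this note shows. Statements on the series, on what has been measured and on what is new or still open speak of the compounds shown alone.

In an ADME assay on MRC5 cells (Homo sapiens) for inhibition, with a stated time of 72 h (a lower number here means that less compound is needed, a higher number that more compound is needed for the effect), compound 1 `COc1cccc(OC)c1C(=O)Nc1c[nH]nc1C(=O)N[C@H]1CC[C@H](O)CC1` gives 34000 nM. Compound 2 `COc1cccc(OC)c1C(=O)Nc1c[nH]nc1C(=O)NC1CC2CCC1C2` gives only a limit, > 50000 nM. Compound 3 `COc1cccc(OC)c1C(=O)Nc1c[nH]nc1C(=O)NCc1ccccn1` also gives only a limit, > 50000 nM. Among the measured compounds shown here, the series so far shows (the limit of > 50000 nM in this assay, at which 2 of the 3 values shown sit).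

Next is compound 4 `COc1cccc(OC)c1C(=O)Nc1c[nH]nc1C(=O)NCC1CCCCC1`, with cyclohexyl in place of pyridin-2-yl on a saturated chain carbon bound to an amide-type nitrogen. Two measured steps change the group on that amide-type nitrogen: an at least 1.4-fold higher number from compound 1 to compound 2 (0.16 log units; that floor lies within the scatter) and an at least 1.4-fold higher number from compound 1 to compound 3 (0.16 log units; that floor lies within the scatter). Between the other pair, the reading is a step that the two limits leave unreadable from compound 2 to compound 3. Neither of the first two steps shows a change beyond the scatter, so none is expected here. The expected step is a number no higher from compound 3 to compound 4 (the limit leaves the size open). For compound 4 the estimate is 50000 nM, with an expected range of 25000 nM to 100000 nM.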

Compound 4, half-maximal effective concentration: > 50000 nM
Compound 4 ended at the assay's limit (the forecaster's own chance of this, stated with the estimate: 65%); the middle value sits exactly at the limit.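

With cyclohexyl in place of pyridin-2-yl on a saturated chain carbon bound to an amide-type nitrogen, compound 4 still gives no number in this assay, only a limit. Against the 4-hydroxycyclohexyl group, cyclohexylmethyl gives an at least 1.4-fold higher number from compound 1 to compound 4 (0.16 log units; that floor lies within the scatter). The steps reaching compound 4 from compound 2 and compound 3 cannot be read, because both ends of each are limits: the limit of > 50000 nM in this assay, at which 3 of the 4 values shown sit.

As far as these compounds go, how far compounds 2, 3 and 4 lie past that limit stays open. Also open, from the compounds shown here alone, is whether an amine or a carboxylic acid in place of the hydroxyl of compound 1 would shift the read-out beyond the scatter.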